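A few compounds are considered here, and "the series" means these few. Any claim that something is new, unique, unknown or untested is made for them only; others in the source may bear on it.

Compound 3 `COc1ccc2c(OCc3nnc4sc(-c5ccncc5)nn34)ccnc2c1` is one of three close relatives that share a core and differ only in the aromatic ring attached to it. In a functional assay on EBC-1 cells (Homo sapiens) for antiproliferative activity, with a stated time of 72 h (on this read-out lower numbers stand for stronger inhibition and higher numbers for weaker inhibition), compound 3 gives 289 nM. That number is the second highest of the three: compound 1 `COc1ccc2c(OCc3nnc4sc(-c5cc[nH]c5)nn34)ccnc2c1` gives 353 nM, and the step of a 1.2-fold lower number from compound 1 to compound 3 (0.09 log units; within the scatter) stays within the usual scatter, while compound 2 `COc1ccc2c(OCc3nnc4sc(-c5cnn(C)c5)nn34)ccnc2c1` gives 88 nM, and the step of a 3.3-fold higher number from compound 2 to compound 3 (0.52 log units; beyond the scatter) lies beyond it.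

Compound 4 `COc1ccc2c(OCc3nnc4sc(-c5cc(F)c(F)c(F)c5)nn34)ccnc2c1` is not yet measured. It differs from compound 3 in one place: 3,4,5-trifluorophenyl in place of pyridin-4-yl on an aromatic carbon. Among the compounds with values here, none of the measured steps swaps a ring with a hydrogen-bond acceptor for one without, or adds fluorine, so they bear on this change only loosely. They show that changing this ring moves this assay by modest amounts at most, as seen in a 4.0-fold lower number from compound 1 to compound 2 (0.60 log units; beyond the scatter) and a 3.3-fold higher number from compound 2 to compound 3 (0.52 log units; beyond the scatter). For compound 4 the expected step is therefore small and its direction uncertain, a 1.4-fold higher number from compound 3 to compound 4 (0.14 log units; within the scatter). The estimate for compound 4 is 400 nM, expected to fall between 120 nM and 1500 nM.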

Compound 4, half-maximal inhibitory concentration: 403 nM
Estimate against measurement, compound 4: 1.0-fold (0.00 log units) below; the measured number falls inside the stated range.
By their numbers in this assay, from the lowest: compound 2; then compounds 3, 1 and 4 (each within the scatter of the next).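

Putting 3,4,5-trifluorophenyl in place of pyridin-4-yl, a 1.4-fold higher number from compound 3 to compound 4 (0.14 log units; within the scatter), shows that in this assay this position tolerates a ring of carbon only, with 0 hydrogen-bond acceptors, so the ring nitrogen of compound 3 is not needed to reach this level. Very different rings can therefore give similar numbers here, as a 1.1-fold higher number from compound 1 to compound 4 (0.06 log units; within the scatter) also shows, while 1-methyl-1H-pyrazol-4-yl remains the one ring that stands apart, with a 4.6-fold higher number from compound 2 to compound 4 (0.66 log units; beyond the scatter) joining its steps to compound 1 and compound 3 beyond the scatter. Nothing available here explains why that ring gives the lowest number.

As far as these compounds go, whether the fluorine atoms of compound 4 matter at all remains open, since a plain phenyl ring would be needed to separate their contribution from that of the ring itself. Also open, from the compounds shown here alone, is how this position responds to a ring carrying an amine or a carboxylic acid.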